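A few compounds are considered here, and "the series" means these few. Any claim that something is new, unique, unknown or untested is made for them only; others in the source may bear on it.

Measured in a physicochemical assay for lipophilicity, read by HPLC, at pH 7.5; a lower number here means a more polar compound, a higher number a more lipophilic compound:
Compound 1 `CC[C@@H](Nc1c(C#N)c(-c2ccc(Br)cc2)nc2cnccc12)C(=O)O`: 1.6
Compound 2 `CCOc1ccccc1-c1ccc(-c2nc3cnccc3c(N[C@H](CC)C(=O)O)c2C#N)cc1`: 2.1

Of these two, compound 2 stands higher, at 2.1. Compound 3 `CC[C@@H](Nc1c(C#N)c(-c2ccc(-c3cccc(C)c3F)cc2)nc2cnccc12)C(=O)O` carries 2-fluoro-3-methylphenyl in place of 2-ethoxyphenyl on an aromatic carbon. Going by the values given here, only one measured step bears on this change: the modest a number 0.50 log units higher from compound 1 to compound 2 (beyond the scatter), which brought in 2-ethoxyphenyl in place of bromo. Among the compounds with values here, no measured step exchanges one substituted phenyl for another, so no shift beyond the scatter is expected in this assay. The expected value for compound 3 is 2.2, with an estimated range of 1.8 to 2.6. This estimate means an expected a number 0.10 log units higher from compound 2 to compound 3 (within the scatter).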

Compound 3, distribution coefficient: 2.1
Compound 3: middle estimate off by 0.10 log units, on the high side; the range from low to high includes it.
By their numbers in this assay, from the lowest: compound 1; then compounds 2 and 3 (each within the scatter of the next).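

In this assay, one substituted phenyl for another at this position, para to a large group, gives no change at the digits printed from compound 2 to compound 3 (within the scatter) and so no shift beyond the scatter, even though the two groups differ in their atoms. Set against bromo, 2-fluoro-3-methylphenyl gives a number 0.50 log units higher from compound 1 to compound 3 (beyond the scatter) and so matches the step that 2-ethoxyphenyl gave. No evidence here accounts for the two groups reading alike.

Going by these compounds, it remains open whether this holds for a phenyl carrying an amine or a carboxylic acid. On these data alone, it is also open whether a longer chain in place of the ring would give the same reading.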